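Swapping the pyrimidinyl group on a thiourea herbicide

A few compounds are considered here, and "the series" means these few. Any claim that something is new, unique, unknown or untested is made for them only; others in the source may bear on it.

Compound 1 `COc1cc(Cl)nc(NC(=S)NC(=O)c2c(-c3ccc(Cl)cc3Cl)noc2C)n1` was tested in a functional assay on the whole organism (strain L.) for inhibition, with Echinochloa crus-galli as the target, with a stated time of 72 h, tested at 100 mg/L (on this read-out lower numbers stand for less inhibition of growth and higher numbers for more inhibition of growth at the one concentration tested), and gives 56.3%. Compound 2 `COc1cc(SC)nc2n/c(=N/C(=O)c3c(-c4ccc(Cl)cc4Cl)noc3C)sn12`, measured in the same way, gives 55.6% in this assay. Compound 1 holds the higher of the two numbers, but the gap to compound 2 lies within the usual scatter, so the two results tell nothing about an order between them. Compound 3 `Cc1cc(C)nc(NC(=S)NC(=O)c2c(-c3ccc(Cl)cc3Cl)noc2C)n1` has not yet been measured. It differs from compound 1 by 4,6-dimethylpyrimidin-2-yl in place of 4-chloro-6-methoxypyrimidin-2-yl on an amide-type nitrogen. For the measured compounds named here, no pair of measured compounds shows what this kind of exchange does in this assay, so there is no measured step to lean on. With only the two close results of compound 1 and compound 2 as a guide, compound 3 is expected to stay near them, with a step from compound 1 to compound 3 of a number 8.3 percentage points lower from compound 1 to compound 3 (within the scatter) that is expected to lie within the scatter or only slightly below it. Compound 3 is therefore estimated to give 48% in this assay, within a range from 20% to 75%.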

Compound 3, percent growth inhibition at one concentration: 64.7%
Estimate against measurement, compound 3: 16.7 percentage points below; low and high end bracket the measured number.
By their numbers in this assay, from the lowest: compounds 2, 1 and 3 (each within the scatter of the next).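

For the compounds shown here, on the amide-type nitrogen whose other neighbour is the thiocarbonyl carbon, the exchange of 4-chloro-6-methoxypyrimidin-2-yl for 4,6-dimethylpyrimidin-2-yl is the first step at this position that can be read in this assay, and it amounts to a number 8.4 percentage points higher from compound 1 to compound 3 (within the scatter). The position therefore accepts a pyrimidinyl group carrying neither the chlorine nor the methoxy, with the inhibition of growth at the one concentration tested staying within the scatter, so neither of these two substituents is required to hold this level of inhibition on the shared core. Nothing at hand gives a measured reason for how this exchange behaves.

Going by these compounds, the chlorine and the methoxy leave together in this single step, so what each contributes alone remains open, as does any order between compound 1 and compound 3. Also open, on these data alone, is how far the position stretches beyond a pyrimidinyl group, for instance whether an amine or a longer chain such as butyl on the same amide-type nitrogen would keep the inhibition of growth in this range.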